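Swapping thiophene for furan on a weakly active nucleoside

The source may hold more compounds than are shown below. What is called first, only, known or untested is meant among the compounds shown, and "the series" means these compounds.

Measured so far:
Compound 1, `CN(C)c1ncnc2c1c(-c1ccsc1)cn2[C@@H]1O[C@H](CO)[C@@H](O)[C@H]1O`: > 100000 nM
Compound 2, `C#Cc1cn([C@@H]2O[C@H](CO)[C@@H](O)[C@H]2O)c2ncnc(C)c12`: 50 nM

Of the compounds shown here, two have been tested in an ADME assay on BJ cells (Homo sapiens), read by MTT assay, with a stated time of 72 h; on this read-out higher numbers stand for weaker inhibition and lower numbers for stronger inhibition. Compound 1 returned only > 100000 nM, which is a limit of this assay and not a measured number. Compound 2, a different design around the same sugar, gave 50 nM in this assay. The two compounds differ in more than one place, so their values are compared here only as they stand: one sits at the limit, the other far from it, as noted in the limit of > 100000 nM in this assay, at which 1 of the 2 values shown sits.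

Compound 3, `CN(C)c1ncnc2c1c(-c1ccoc1)cn2[C@@H]1O[C@H](CO)[C@@H](O)[C@H]1O`, is not yet measured. It differs from compound 1 by a single change: furan-3-yl in place of thiophen-3-yl on an aromatic carbon. Among the measured compounds shown here, no step of this kind between measured compounds is available for comparison. Given that compound 1 shows no measurable inhibition in this assay, the expectation is that exchanging one five-membered aromatic ring for a closely related one will produce no step beyond the usual scatter, so that compound 3 most likely also reaches the limit.

The estimated step from compound 1 to compound 3 is therefore a number no higher from compound 1 to compound 3 (the limit leaves the size open). Compound 3 is expected to give about 100000 nM in this assay, within a range from 30000 nM to 300000 nM.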

Compound 3, half-maximal inhibitory concentration: 99200 nM
For compound 3 the middle estimate is 1.0-fold (0.00 log units) above the measured one, and the stated range covers the measured number.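

In this assay compound 3 gives 99200 nM, so with furan-3-yl on this aromatic carbon the shared core now has a real number. It is a high one that stands for weak inhibition, but later changes can be measured against it. For compound 1, > 100000 nM is a limit of this assay and not a number. The exchange of thiophen-3-yl for furan-3-yl gives a number no higher from compound 1 to compound 3 (the limit leaves the size open). It therefore cannot be called a gain or a loss, because one end of the step rests on a limit and its size cannot be read: the limit of > 100000 nM in this assay, at which 1 of the 3 values shown sits.

From the compounds shown here alone, both rings seen at this carbon are five-membered aromatic rings with one hetero atom, so it remains open what a phenyl ring or a short chain such as propyl would give there. Also open, going by these compounds, is whether a lower number needs a change at this carbon at all, or a change elsewhere on the core, such as a primary amine in place of the dimethylamino group.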